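Methoxy Added to a Compound Held at a Limit

A few compounds are considered here, and "the series" means these few. Any claim that something is new, unique, unknown or untested is made for them only; others in the source may bear on it.

In a functional assay on KB cells (Homo sapiens) for inhibition (on this read-out higher numbers stand for weaker inhibition and lower numbers for stronger inhibition), compound 1 (`Nc1nc2cc(Cl)c(Cl)cc2n1Cc1ccccc1`) gives 170000 nM. Compound 2 (`Nc1nc2cc(Cl)c(Cl)cc2n1Cc1cccc(C(F)(F)F)c1`) gives 45000 nM, which is a 3.8-fold lower number from compound 1 to compound 2 (0.58 log units; beyond the scatter), with trifluoromethyl in place of hydrogen on an aromatic carbon. Compound 3 (`Clc1cc2nc(Cl)n(Cc3ccccc3)c2cc1Cl`) has chloro in place of amino on an aromatic carbon. Compound 3 is reported only as a limit, > 100000 nM, and not as a number. From the compounds shown here alone, the result is a step that the limit leaves unreadable from compound 1 to compound 3, so its true position on the scale remains unknown.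

Compound 4 (`COc1ccc(Cn2c(Cl)nc3cc(Cl)c(Cl)cc32)cc1`) differs from compound 3 by methoxy in place of hydrogen on an aromatic carbon, para to a large group. Within the data shown here, no measured step involves methoxy. The nearest guide is the change from compound 1 to compound 2, also a replacement of hydrogen on an aromatic carbon, which was a 3.8-fold lower number from compound 1 to compound 2 (0.58 log units; beyond the scatter). That single modest step, made with a different group, supports only a cautious expectation of a similarly modest move toward stronger inhibition in this assay. The expected step is an at least 1.1-fold lower number from compound 3 to compound 4 (0.04 log units; that floor lies within the scatter), and it may well leave the reading at the limit. For compound 4 the estimated value is 90000 nM, with an expected range from 30000 nM to 250000 nM.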

Compound 4, half-maximal inhibitory concentration: > 100000 nM
Compound 4: a limit, no number; the forecaster's own chance of this, stated with the estimate: 50%; at least 1.1-fold (0.04 log units) between middle value and limit.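

In this assay, among these compounds, compound 3 and compound 4 are both reported only as limits and not as numbers, so no step between them can be read: the limit of > 100000 nM in this assay, at which 2 of the 4 values shown sit.

The compounds shown leave open whether methoxy in place of hydrogen on an aromatic carbon changes inhibition at all, and where on the scale compound 3 and compound 4 truly lie.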